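This account rests on a few compounds, and the source may have more. Where it says the series, first, only, none or still open, it means among the compounds named here.

Of the compounds shown here, three sharing one core have been measured in an assay on CHO cells for positive allosteric modulation of metabotropic glutamate receptor 5 (Homo sapiens), read by FLIPR; on this read-out lower numbers stand for an effect already at smaller amounts and higher numbers for an effect only at larger amounts of compound. Compound 1 `O=C(Nc1ccc(Cl)cc1CN1C(=O)c2ccccc2C1=O)c1ccccc1` bears an unsubstituted phenyl on the carbonyl carbon; in this assay compound 1 gives only a limit, > 100000 nM, as noted in the limit of > 100000 nM in this assay, at which 1 of the 3 values shown sits. Compound 2 `O=C(Nc1ccc(Cl)cc1CN1C(=O)c2ccccc2C1=O)c1ccccc1C(F)(F)F` carries 2-(trifluoromethyl)phenyl on that carbon, and in this assay compound 2 gives 5700 nM. Compound 3 `O=C(Nc1ccc(Cl)cc1CN1C(=O)c2ccccc2C1=O)c1ncccn1` carries pyrimidin-2-yl there and in this assay gives 2100 nM. Compound 3 thus stands at the lowest of the two numbers shown, with compound 2 nearest: a 2.7-fold lower number from compound 2 to compound 3 (0.43 log units; beyond the scatter). The move from compound 1 was larger: an at least 47-fold lower number from compound 1 to compound 3 (1.67 log units; beyond the scatter).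

Compound 4 `O=C(Nc1ccc(Cl)cc1CN1C(=O)c2ccccc2C1=O)c1cncs1` is not yet measured. It differs from compound 3 in one place: 1,3-thiazol-5-yl in place of pyrimidin-2-yl on a carbonyl carbon. Both measured steps at this position were changes of the ring on the carbonyl carbon, and both moved the number by a large or modest amount, so this position is sensitive. Within the data shown here, no measured step replaces a six-membered heteroaromatic ring with a five-membered one, so the direction is uncertain. Since compound 3 already holds the lowest number, a modest rise is expected: a 1.9-fold higher number from compound 3 to compound 4 (0.28 log units; within the scatter). The estimate for compound 4 in this assay is 4000 nM, expected to fall between 1000 nM and 20000 nM.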

Compound 4, half-maximal effective concentration: 1900 nM
Compound 4: the middle estimate sits 2.1-fold (0.32 log units) above what was measured; the range from low to high includes it.
By their numbers in this assay, from the lowest: compounds 4 and 3 (each within the scatter of the next); then compound 2. At a limit, above all of these: compound 1.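

Among these compounds, what the earlier compounds did not show is that a five-membered ring containing sulfur can take the place of the six-membered pyrimidin-2-yl on this carbonyl carbon with no step beyond the scatter in this assay: a 1.1-fold lower number from compound 3 to compound 4 (0.04 log units; within the scatter). The 2-(trifluoromethyl)phenyl ring stays clearly apart from the new ring, with a 3.0-fold lower number from compound 2 to compound 4 (0.48 log units; beyond the scatter), so the two heteroaromatic rings now stand together on one side of that gap. The step from the unsubstituted phenyl, an at least 52-fold lower number from compound 1 to compound 4 (1.72 log units; beyond the scatter), gives no exact size, as it rests on a value that is only a limit: the limit of > 100000 nM in this assay, at which 1 of the 4 values shown sits.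

The compounds shown carry only aromatic rings on this carbonyl carbon, and both heteroaromatic rings contain nitrogen, so they leave open how a thiophene ring, with sulfur but no nitrogen, or a saturated piperidine ring would read out there. From the compounds shown here alone, all four compounds also share the rest of the core unchanged, so what a methoxy group or a nitrile in place of its chlorine would do remains unknown.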